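The source may hold more compounds than are shown below. What is called first, only, known or untested is meant among the compounds shown, and "the series" means these compounds.

Three compounds sharing the core were put to a functional assay on a cell-free system (Platelet, plasma, Homo sapiens) for inhibition; a lower number here means a stronger inhibitor, a higher number a weaker inhibitor. In that assay compound 1 (`O=C(Nc1cccc(OCc2ccccc2)c1)C1CCCNC1`) is recorded as "not determined" (no result reported), and compound 3 (`O=C(Nc1cccc(OCc2ccccc2)c1)C1CCNCC1`) is also recorded as "not determined" (no result reported), so compound 3 has no number of its own. Only compound 2 (`O=C(Nc1ccc(OCc2ccc(F)cc2)cc1)C1CCCNC1`) has a figure, 90000 nM. Compound 4 (`O=C(Nc1cccc(OCc2ccc(-c3ccc(F)cc3)cc2)c1)C1CCNCC1`) comes from compound 3 by a single change, 4-fluorophenyl in place of hydrogen on an aromatic carbon, para to a large group. Within the data shown here, no measured step gives a scale for this change, so the expectation is loose: a moderate move toward stronger inhibition in this assay, given the weak reading of compound 2 at 90000 nM. The estimated value for compound 4 is 12000 nM, with an expected range of 2000 nM to 70000 nM.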

Compound 4, half-maximal inhibitory concentration: 19000 nM
Compound 4: the middle estimate sits 1.6-fold (0.20 log units) below what was measured; the range from low to high includes it.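

In this assay, among these compounds, compound 3 has no single number, so no step to compound 4 can be read. As far as these compounds go, what 4-fluorophenyl in place of hydrogen does to inhibition stays open. Nothing shown explains the reading of compound 4.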